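Bromo for methyl on two indole-bearing diterpenoid cores

The source may report more compounds than this note shows. Statements on the series, on what has been measured and on what is new or still open speak of the compounds shown alone.

Measured compounds: compound 1 `COC(=O)[C@@]1(C)CCC=C2[C@@H]1CC[C@@H](C)[C@]2(C)Cc1c(C)[nH]c2ccc(C)cc12` with 25000 nM; compound 2 `COC(=O)[C@@]1(C)CCC=C2[C@@H]1CC[C@@H](C)[C@]2(C)Cc1c(C)[nH]c2ccc(Br)cc12` with 15000 nM; compound 3 `COC(=O)[C@@]1(C)CC[C@@H]2C3=C1CC[C@@H](C)[C@]3(C)Cc1c2[nH]c2c(C)cccc12` with 13000 nM.

In a functional assay on HBL-100 cells (Homo sapiens) for inhibition, read by sulforhodamine B assay, with a stated time of 48 h (a higher number here means a weaker inhibitor of growth, a lower number a stronger inhibitor of growth), compound 1 gives 25000 nM and compound 2 gives 15000 nM. The change between them, (bromo in place of methyl on an aromatic carbon), made a step of a 1.7-fold lower number from compound 1 to compound 2 (0.22 log units; within the scatter). Compound 3, built on a different core, gives 13000 nM; the difference between the two cores is not broken down here.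

Compound 4 `COC(=O)[C@@]1(C)CC[C@@H]2C3=C1CC[C@@H](C)[C@]3(C)Cc1c2[nH]c2c(Br)cccc12` carries the same kind of change, (bromo in place of methyl on an aromatic carbon), but the place differs: in compound 4 the aromatic carbon is part of a fused or bridged system of five rings, ortho to a fused ring and meta to a fused ring, whereas in compound 2 it is part of a system of two rings, meta and para to a fused ring. Because the earlier step was a 1.7-fold lower number from compound 1 to compound 2 (0.22 log units; within the scatter), the step for compound 4 is expected to be a 1.3-fold lower number from compound 3 to compound 4 (0.11 log units; within the scatter). Compound 4 is thus estimated at 10000 nM, between 5000 nM and 25000 nM.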

Compound 4, concentration for 50% growth inhibition: 26000 nM
Compound 4: middle estimate off by 2.6-fold (0.41 log units), on the low side; measured number above the stated range.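

In this assay, bromo in place of methyl on an aromatic carbon gave a 2.0-fold higher number from compound 3 to compound 4 (0.30 log units; within the scatter), and set beside the earlier step, the change does not carry over unaltered from one core to the other: the same change on two cores in this assay, a 1.7-fold lower number (0.22 log units; within the scatter) from compound 1 to compound 2 and a 2.0-fold higher number (0.30 log units; within the scatter) from compound 3 to compound 4, 3.3-fold (0.52 log units) apart, beyond the scatter of two such steps. Each step taken alone stays within the scatter, so neither one shows an effect of the change on its own core. The core and the place of the change differ together between the two pairs, so these compounds do not show which of the two lies behind the gap.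

Left open is whether chloro, methoxy or an amine on these aromatic carbons would follow either step. Also open, from the compounds shown here alone, is how a carboxylic acid in place of the methyl ester would read on either core.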